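The source may report more compounds than this note shows. Statements on the series, on what has been measured and on what is new or still open speak of the compounds shown alone.

Measured compounds:
compound 1 `Cc1cc(C(=O)NCN2CCC(c3cccc[n+]3[O-])CC2)ccc1F` — 50 nM
compound 2 `Cc1cc(NC(=O)CN2CCC(c3cccc[n+]3[O-])CC2)ccc1F` — 18 nM
compound 3 `COc1cc(C(=O)NCN2CCC(c3cccc[n+]3[O-])CC2)ccc1Cl` — 159 nM

Of the compounds shown here, three have been measured in a functional assay on HEK293 cells for agonist activity at D(4) dopamine receptor (Homo sapiens), read by FLIPR; on this read-out higher numbers stand for an effect only at larger amounts of compound and lower numbers for an effect already at smaller amounts. Compound 1 stands second highest of the three numbers: compound 2 shows a lower number that lies beyond the usual scatter, and compound 3 shows a higher number that also lies beyond it. Compound 1 therefore sits in the middle of the range seen so far.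

Compound 4 `O=C(NCN1CCC(c2cccc[n+]2[O-])CC1)c1ccccn1` has not yet been measured. It differs from compound 1 in one place: pyridin-2-yl in place of 4-fluoro-3-methylphenyl on a carbonyl carbon. The aromatic ring attached to the carbonyl carbon thus changes from a six-membered ring of carbon only to a six-membered ring containing one nitrogen, and the two substituents on that ring are gone.

Among the compounds with values here, no pair among the measured compounds isolates this kind of change, so the expectation rests on compound 1 alone. The step of a 3.0-fold higher number from compound 1 to compound 4 (0.48 log units; beyond the scatter) is expected to move toward a higher number, that is, an effect only at somewhat larger amounts of compound, by more than the scatter. For compound 4 in this assay the estimate is 150 nM, with a range from 40 nM to 600 nM.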

Compound 4, half-maximal effective concentration: 3150 nM
The estimate for compound 4 lay 21-fold (1.32 log units) below the measured number, outside the stated range (above it).
By their numbers in this assay, from the lowest: compound 2; then compound 1; then compound 3; then compound 4.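

In this assay the aromatic group on the carbonyl carbon proves to matter greatly: pyridin-2-yl in place of 4-fluoro-3-methylphenyl brings a 63-fold higher number from compound 1 to compound 4 (1.80 log units; beyond the scatter) and so an effect only at far larger amounts of compound. This is the only step at this position among the compounds shown, and it leaves compound 4 with the highest number of the four. Nothing available here explains why this step is so large.

Going by these compounds, the change brings in a ring nitrogen and removes both the fluorine and the methyl group in one move, so the share of each in the step remains open. A plain phenyl or a 4-fluorophenyl group on the same carbonyl carbon would help separate these parts, and a pyridin-3-yl group would show whether the place of the ring nitrogen matters.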